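Cytotoxicity notes: methoxymethyl added to compound 2

A few compounds are considered here, and "the series" means these few. Any claim that something is new, unique, unknown or untested is made for them only; others in the source may bear on it.

Compound 2 `Fc1cccc(Nc2c(-c3ccccn3)nc3ccccn23)c1` gives in an ADME assay on THP-1 cells (Homo sapiens) for cytotoxicity (a higher number here means that more compound is tolerated, a lower number that less compound is tolerated), only a limit, > 50000 nM. Compound 1 `c1ccc(CNc2c(-c3ccccn3)nc3ccccn23)cc1` likewise reaches only a limit in this assay, > 50000 nM. Compound 3 `N#Cc1ccc(Nc2c(-c3ccccn3)nc3ccccn23)cc1` also sits at a limit in this assay, > 50000 nM. The steps a step that the two limits leave unreadable from compound 1 to compound 2, a step that the two limits leave unreadable from compound 1 to compound 3 and a step that the two limits leave unreadable from compound 2 to compound 3 can therefore not be sized in either direction; all that the series shows is the limit of > 50000 nM in this assay, at which 3 of the 3 values shown sit.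

Compound 4 `COCc1ccn2c(Nc3cccc(F)c3)c(-c3ccccn3)nc2c1` differs from compound 2 by methoxymethyl in place of hydrogen on an aromatic carbon; the new group sits on an aromatic carbon of a six-membered aromatic ring with 1 nitrogen, part of a fused or bridged system of two rings, meta to a fused ring, opposite the ring nitrogen and para to a fused ring. Within the data shown here, none of the measured steps changes this ring, and none of them can be read as a size, so they give no direction for the new change. With every measured value resting at the limit, compound 4 is expected to remain at or near that limit, and the step of a number no higher from compound 2 to compound 4 (the limit leaves the size open) is expected to be essentially nil. Compound 4 is estimated at 50000 nM in this assay, within 25000 nM to 100000 nM, with a strong chance that only a limit is reported again.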

Compound 4, half-maximal cytotoxic concentration: 7370 nM
For compound 4 the middle estimate is 6.8-fold (0.83 log units) above the measured one, and the stated range ends above it.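

Methoxymethyl in place of hydrogen on an aromatic carbon gives an at least 6.7-fold lower number from compound 2 to compound 4 (0.83 log units; beyond the scatter) in this assay, the first step in the series with a readable lower bound on its size; the steps among compound 1, compound 2 and compound 3 cannot be read. Among these compounds, this position, on the ring and opposite the ring nitrogen, is therefore one where a change to the shared core moves the number, whereas the earlier compounds differ only in the group on the nitrogen and leave this ring unchanged. Compound 4 is also the only compound shown with a value off the limit: the limit of > 50000 nM in this assay, at which 3 of the 4 values shown sit.

Going by these compounds, whether the step depends on the oxygen of methoxymethyl or would follow any group on this carbon remains open, and a methyl, a hydroxymethyl, a longer ether chain, an amine or a carboxylic acid at the same position would help separate those readings. Also open, on these data alone, is whether methoxymethyl at this position would give a step of similar size with the benzyl group of compound 1 or the 4-cyanophenyl group of compound 3 on the nitrogen.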